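Benzyl for isopropyl at the amine tail: expectation

The compounds below may be only part of what the source reports. "The series", "measured", "known", "first", "only" and "open" are said of these compounds alone.

Measured compounds:
- compound 1 `c1ccc(OCc2nc3c(OCCCN4CCCCC4)cccc3n2CCCC2CCN(CC3CCCCC3)CC2)cc1`: in an in vitro assay on AV12 cells for binding affinity to Neuropeptide Y receptor type 1 (Homo sapiens) (a lower number here means a stronger inhibitor, a higher number a weaker inhibitor), compound 1 gives 0.393 nM
- compound 2 `CC(C)CCN1CCC(CCCn2c(COc3ccccc3)nc3c(OCCCN4CCCCC4)cccc32)CC1`: in this assay compound 2 gives 0.29 nM

Compound 2 holds the lowest of the two numbers, with compound 1 nearest; the step of a 1.4-fold lower number from compound 1 to compound 2 (0.13 log units; within the scatter) lies within the scatter, so the two cannot be ordered.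

Compound 3 `c1ccc(CCCN2CCC(CCCn3c(COc4ccccc4)nc4c(OCCCN5CCCCC5)cccc43)CC2)cc1` differs from compound 2 by benzyl in place of isopropyl on a saturated chain carbon, two bonds along the chain from an amine nitrogen in a ring. Going by the values given here, the only measured step that bears on this position is the one from compound 1 to compound 2, which exchanged cyclohexyl for isobutyl on the saturated chain carbon bound to the amine nitrogen in the ring and produced a change within the scatter. The present change likewise alters only the tail on that chain, exchanging a three-carbon branch for a six-membered aromatic ring of carbon only. With a single relevant step of this size, no movement beyond the scatter is expected in this assay; the direction cannot be called.

Compound 3 is therefore estimated at 0.35 nM in this assay, range 0.12 nM to 1 nM, which amounts to an expected step of a 1.2-fold higher number from compound 2 to compound 3 (0.08 log units; within the scatter).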

Compound 3, inhibition constant: 0.361 nM
Beside the measured number, compound 3's estimate is 1.0-fold (0.01 log units) below it; the measured number falls inside the stated range.
By their numbers in this assay, from the lowest: compounds 2, 3 and 1 (each within the scatter of the next).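

In this assay benzyl in place of isopropyl gives a 1.2-fold higher number from compound 2 to compound 3 (0.10 log units; within the scatter) and so brings a six-membered aromatic ring of carbon only to this place and raises the group from 3 to 7 heavy atoms, without a step that can be told from the scatter. The comparison with the saturated ring reads a 1.1-fold lower number from compound 1 to compound 3 (0.04 log units; within the scatter) and so, with phenethyl in place of cyclohexyl on the saturated chain carbon bound to the amine nitrogen in the ring, cyclohexyl and the aromatic ring cannot be ordered here, and compounds 1, 2 and 3 show no step beyond the scatter among them. Nothing available explains why these tails read alike.

Open, as far as these compounds go, is whether any tail at this place moves the number beyond the scatter, for instance a carboxylic acid or an amide at the end of the chain, or a single methyl on the ring amine nitrogen in place of the longer chains. From the compounds shown here alone, the aromatic ring of compound 3 is unsubstituted, so the reading with a fluorine or a methoxy on that ring also remains open.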